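Replacing 3-chlorophenyl with 4-hydroxyphenyl on a shared core

This account rests on a few compounds, and the source may have more. Where it says the series, first, only, none or still open, it means among the compounds named here.

Of the compounds shown here, three with a shared core have been measured in a functional assay on HT-29 cells (Homo sapiens) for antiproliferative activity, read by MTT assay, with a stated time of 48 h; on this read-out lower numbers stand for stronger inhibition of growth and higher numbers for weaker inhibition of growth. Compound 1 `COC(=O)N1N=C(c2ccccc2)CC1c1cc(OC)c(OC)c(OC)c1` gives 6260 nM, compound 2 `COC(=O)N1N=C(c2ccc(OC)cc2)CC1c1cc(OC)c(OC)c(OC)c1` gives 2550 nM, and compound 3 `COC(=O)N1N=C(c2cccc(Cl)c2)CC1c1cc(OC)c(OC)c(OC)c1` gives 140 nM, the lowest of the three numbers and the strongest inhibition of growth in this small set.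

The next structure, compound 4 `COC(=O)N1N=C(c2ccc(O)cc2)CC1c1cc(OC)c(OC)c(OC)c1`, has not yet been measured. It departs from compound 3 by 4-hydroxyphenyl in place of 3-chlorophenyl on a carbon with a double bond to nitrogen, with 4-hydroxyphenyl in place of 3-chlorophenyl on a carbon with a double bond to nitrogen.

Among the measured compounds shown here, three measured steps bear on this change. Chloro in place of hydrogen on an aromatic carbon gave a large step, a 45-fold lower number from compound 1 to compound 3 (1.65 log units; beyond the scatter). Methoxy in place of hydrogen on an aromatic carbon gave only a modest one, a 2.5-fold lower number from compound 1 to compound 2 (0.39 log units; beyond the scatter). The swap of 4-methoxyphenyl for 3-chlorophenyl gave another large step, an 18-fold lower number from compound 2 to compound 3 (1.26 log units; beyond the scatter). Compound 4 has no chloro, and its 4-hydroxyphenyl resembles the 4-methoxyphenyl of compound 2 more closely than the 3-chlorophenyl of compound 3.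

A large step towards a higher number is therefore expected, estimated as a 21-fold higher number from compound 3 to compound 4 (1.33 log units; beyond the scatter). Compound 4 is estimated at 3000 nM, with an expected range of 900 nM to 10000 nM.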

Compound 4, concentration for 50% growth inhibition: 6770 nM
For compound 4 the middle estimate is 2.3-fold (0.35 log units) below the measured one, within the range that was stated.
By their numbers in this assay, from the lowest: compound 3; then compound 2; then compounds 1 and 4 (each within the scatter of the next).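

In this assay, the new result shows that an oxygen group on the 4-hydroxyphenyl does not recover what the 3-chlorophenyl provides at this carbon with a double bond to nitrogen: the change gives a 48-fold higher number from compound 3 to compound 4 (1.68 log units; beyond the scatter). Until now, the only oxygen-bearing ring on this carbon was the 4-methoxyphenyl of compound 2, and removing its methyl, hydrogen in place of methyl on the oxygen, gives a 2.7-fold higher number from compound 2 to compound 4 (0.42 log units; beyond the scatter), so the modest advantage of compound 2 does not carry over to the free hydroxy. Hydroxy in place of hydrogen on the aromatic carbon gives a 1.1-fold higher number from compound 1 to compound 4 (0.03 log units; within the scatter), which leaves compound 4 indistinguishable from compound 1, so among the compounds shown, the low number of compound 3 stands apart from those of the unsubstituted phenyl and both 4-substituted rings.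

Still open, going by these compounds, is whether that low number belongs to the chloro itself or to its place on the ring, a question that a 4-chlorophenyl, a 3-hydroxyphenyl or a 3-aminophenyl on the shared core could help to separate. Nothing measured here accounts for the size of these steps.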